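Cell tolerance when methoxycarbonyl replaces (dimethylamino)methyl

This account rests on a few compounds, and the source may have more. Where it says the series, first, only, none or still open, it means among the compounds named here.

- Compound 1 `CCCC(=O)OCSc1ccccc1C(=O)NCCCCCCC(N)=O`: 10.4 uM
- Compound 2 `CCCC(=O)OCSc1ccccc1C(=O)NCC(=O)NC`: > 100 uM (a limit of the assay)
- Compound 3 `CCCC(=O)OCSc1ccccc1C(=O)NCC(=O)NCCN(C)C`: 76.9 uM

These values come from an ADME assay on CEM-SS cells (Homo sapiens) for cytotoxicity, read by XTT assay, with a stated time of 6 days; a higher number here means that more compound is tolerated, a lower number that less compound is tolerated. Among the two true numbers, compound 3 stands higher at 76.9 uM, and the step of a 7.4-fold higher number from compound 1 to compound 3 (0.87 log units; beyond the scatter) lies beyond the scatter. Compound 2 reads > 100 uM, which is a limit and not a number.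

Compound 4 `CCCC(=O)OCSc1ccccc1C(=O)NCC(=O)NCC(=O)OC` differs from compound 3 in one place: methoxycarbonyl in place of (dimethylamino)methyl on a saturated chain carbon bound to an amide-type nitrogen. Methoxycarbonyl takes the place of (dimethylamino)methyl on a saturated chain carbon bound to an amide-type nitrogen.

The closest evidence is the step at that same place, an at least 1.3-fold lower number from compound 2 to compound 3 (0.11 log units; that floor lies within the scatter), where hydrogen gave way to (dimethylamino)methyl. It is only a floor, and that floor lies within the scatter. The larger steps, an at least 9.6-fold higher number from compound 1 to compound 2 (0.98 log units; beyond the scatter) and a 7.4-fold higher number from compound 1 to compound 3 (0.87 log units; beyond the scatter), both replaced 5-carbamoylpentyl, and compound 4 does not bring that group back.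

No step beyond the scatter is therefore expected in this assay, and compound 4 may read only as a limit. The expected step is a 1.2-fold higher number from compound 3 to compound 4 (0.09 log units; within the scatter). For compound 4 the estimate is 95 uM, with an expected range of 45 uM to 200 uM.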

Compound 4, half-maximal toxic concentration: > 100 uM
Compound 4: a limit, no number; the forecaster's own chance of this, stated with the estimate: 50%; at least 1.0-fold (0.02 log units) between middle value and limit.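

In this assay compound 4 gives > 100 uM, which is a limit of the assay and not a number. At a saturated chain carbon bound to an amide-type nitrogen, methoxycarbonyl in place of (dimethylamino)methyl gives an at least 1.3-fold higher number from compound 3 to compound 4 (0.11 log units; that floor lies within the scatter), a floor that does not by itself separate the two compounds, while replacing 5-carbamoylpentyl gives an at least 9.6-fold higher number from compound 1 to compound 4 (0.98 log units; beyond the scatter), so a second group at this place, besides hydrogen, stays clear of the lower number of compound 1. The steps that compare compound 4 with compound 2 cannot be read, because both compounds sit at the same ceiling of the assay: the limit of > 100 uM in this assay, at which 2 of the 4 values shown sit.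

On these data alone, how far compound 2 and compound 4 lie past that limit stays open, and with it the true size of the change from (dimethylamino)methyl to methoxycarbonyl. Also open, as far as these compounds go, is whether a carboxylic acid in place of the methoxycarbonyl, or a longer chain ending in methoxycarbonyl, would keep this tolerance or move towards compound 1, whose side chain differs from the others in both length and end group.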